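Oxygen-ring core, aryl ether variation, antiproliferative activity

This account rests on a few compounds, and the source may have more. Where it says the series, first, only, none or still open, it means among the compounds named here.

Three members of the series have numbers. Compound 1 `NC1=NC2(CCSCC2)N(OCCCOc2cccc(Cl)c2)C(N)=N1` gives 60 nM in a functional assay on A549 cells (Homo sapiens) for antiproliferative activity, read by MTT assay, with a stated time of 72 h; a lower number here means a stronger inhibitor, a higher number a weaker inhibitor. Compound 2 `NC1=NC2(CCOCC2)N(OCCCOc2cccc(Cl)c2)C(N)=N1` gives 150 nM in this assay. Compound 3 `NC1=NC2(CCOCC2)N(OCCCOc2ccc(Cl)c(Cl)c2)C(N)=N1` gives 790 nM in this assay, the highest of the three numbers; the nearest is compound 2 and the furthest is compound 1. Within the data shown here, the one single-point step known so far is a 5.3-fold higher number from compound 2 to compound 3 (0.72 log units; beyond the scatter).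

Compound 4 `NC1=NC2(CCOCC2)N(OCCCOc2ccc(F)cc2)C(N)=N1` is not yet measured. The change is 4-fluorophenyl in place of 3,4-dichlorophenyl on an oxygen on a saturated carbon. Among the measured compounds shown here, the step from compound 2 to compound 3 bears on it in reverse: taking the second chloro away is expected to bring the number back toward that of compound 2, and the further swap of the remaining chloro for fluoro has no measured counterpart. The expected step is therefore a drop, a 3.2-fold lower number from compound 3 to compound 4 (0.50 log units; beyond the scatter), of a size near the known chloro step but with wide uncertainty. Compound 4 is expected to give about 250 nM in this assay, within 80 nM to 800 nM.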

Compound 4, half-maximal inhibitory concentration: 1060 nM
Compound 4: middle estimate off by 4.2-fold (0.63 log units), on the low side; measured number above the stated range.
By their numbers in this assay, from the lowest: compound 1; then compound 2; then compounds 3 and 4 (each within the scatter of the next).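

In this assay the swap at this position, on an oxygen on a saturated carbon, gives a 1.3-fold higher number from compound 3 to compound 4 (0.13 log units; within the scatter), so 4-fluorophenyl and 3,4-dichlorophenyl cannot be told apart on this core. Against 3-chlorophenyl the same group gives a 7.1-fold higher number from compound 2 to compound 4 (0.85 log units; beyond the scatter), which means that of the three aryl groups on this core only 3-chlorophenyl stands apart, and the number at this position does not simply follow the count of halogens on the ring. No measurement shown bears on the reason for this result.

The compounds shown do not separate the identity of the halogen from its place on the ring, a question that 4-chlorophenyl and 3-fluorophenyl on the same core would address. Also open, going by these compounds, is whether a longer chain to the aryl ether, or a nonhalogen group such as methoxy on the ring, would keep the number of compound 2.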